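Methoxy for methyl on the saturated ring carbon

This account rests on a few compounds, and the source may have more. Where it says the series, first, only, none or still open, it means among the compounds named here.

Measured so far:
compound 1, `Cc1cc2c(cc1C(=O)N=C(N)N)S(=O)(=O)CC2(C)O`, 30 nM
compound 2, `Cc1cc2c(cc1C(=O)N=C(N)N)S(=O)(=O)CC2C`, 44 nM

Among the measured compounds shown here, in an assay on cells for inhibition of sodium/hydrogen exchanger (Oryctolagus cuniculus) (on this read-out lower numbers stand for stronger inhibition and higher numbers for weaker inhibition), compound 2 holds the larger of the two numbers, but the only measured step, a 1.5-fold higher number from compound 1 to compound 2 (0.17 log units; within the scatter), is within the scatter, so no ranking between compound 1 and compound 2 follows from it.

Compound 3, `COC1CS(=O)(=O)c2cc(C(=O)N=C(N)N)c(C)cc21`, is not yet measured. It differs from compound 2 by methoxy in place of methyl on a saturated ring carbon. For the measured compounds named here, the one measured step touches the same saturated ring carbon but exchanges a different group, hydroxy against hydrogen, and that step was within the scatter; it therefore bears on the present change only loosely and gives no reason to expect a move beyond the scatter in this assay. The expected step is a 1.1-fold lower number from compound 2 to compound 3 (0.04 log units; within the scatter). The estimate for compound 3 is 40 nM, with a range from 15 nM to 120 nM.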

Compound 3, half-maximal inhibitory concentration: 96 nM
Beside the measured number, compound 3's estimate is 2.4-fold (0.38 log units) below it, and the stated range covers the measured number.
By their numbers in this assay, from the lowest: compounds 1 and 2 (each within the scatter of the next); then compound 3.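

In this assay the saturated ring carbon two ring bonds from the ring sulfur now shows a step beyond the scatter: a 2.2-fold higher number from compound 2 to compound 3 (0.34 log units; beyond the scatter) for methoxy in place of methyl, a modest move but the first at this position that can be read as a change. The other step at this carbon, a 1.5-fold higher number from compound 1 to compound 2 (0.17 log units; within the scatter) for hydrogen in place of hydroxy, stayed within the scatter, so the two exchanges at this carbon do not read alike. Nothing at hand accounts for the higher number with methoxy. 

Open, on these data alone, is whether an ethoxy group, an amine or a carboxylic acid on this carbon would sit nearer to methyl or to methoxy in this read-out. Also open, as far as these compounds go, is whether methoxy would give a similar step on a carbon that also carries methyl, as the corresponding carbon of compound 1 does.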